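From 3-Aminophenyl to 4-Fluorophenyl at the Ring Nitrogen

The source may report more compounds than this note shows. Statements on the series, on what has been measured and on what is new or still open speak of the compounds shown alone.

Of the compounds shown here, two have so far been tested in a functional assay on HL-60 cells (Homo sapiens) for antiproliferative activity, read by MTT assay, with a stated time of 72 h; on this read-out lower numbers stand for stronger inhibition and higher numbers for weaker inhibition. Compound 1 `COc1ccccc1-c1ncnn1-c1cc(OC)c(OC)c(OC)c1` returns only the limit of the assay, > 10000 nM, and not a number. Compound 2 `COc1cc(-c2ncnn2-c2cccc(N)c2)cc(OC)c1OC` likewise returns only the limit, > 10000 nM, rather than a measured value. Within the data shown here, both results therefore sit at the same limit, as the limit of > 10000 nM in this assay, at which 2 of the 2 values shown sit, shows, so no step between them can be sized, and compound 2 stands at that limit with nothing to rank it against. Compound 3 `COc1cc(-c2ncnn2-c2ccc(F)cc2)cc(OC)c1OC` has not yet been tested. It differs from compound 2 in one place: 4-fluorophenyl in place of 3-aminophenyl on an aromatic nitrogen. Among the measured compounds shown here, with no measured step to lean on, the expectation rests on compound 2 alone. In this assay a change of a step that the limit leaves unreadable from compound 2 to compound 3 is expected, which is none beyond the usual scatter. Compound 3 is accordingly estimated at 15000 nM, within a range from 5000 nM to 50000 nM, and it is expected most likely to come back as a limit as well.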

Compound 3, half-maximal inhibitory concentration: > 10000 nM
Compound 3 ended at the assay's limit (the forecaster's own chance of this, stated with the estimate: 80%); the middle value lies beyond the limit too.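

No step from compound 2 to compound 3 can be read, because each of the two compounds returned a limit and not a number: the limit of > 10000 nM in this assay, at which 3 of the 3 values shown sit.

The compounds shown leave open whether 4-fluorophenyl and 3-aminophenyl differ at all in this test, and which change to the shared core would give a measurable value.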